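Phenyl Closes a Shortened Trifluoromethyl Ketone Chain

The source may report more compounds than this note shows. Statements on the series, on what has been measured and on what is new or still open speak of the compounds shown alone.

Compound 1, `CCCCCCCCCCCCCCCCCC(=O)C(F)(F)F`, gives 240 nM in an assay on liver for inhibition of Fatty-acid amide hydrolase 1 (Rattus norvegicus); on this read-out higher numbers stand for weaker inhibition and lower numbers for stronger inhibition.
Compound 2, `CCCCCCCCCCCCCC(=O)C(F)(F)F`, gives 490 nM in this assay.

Among these two numbers compound 2 stands at the higher one, and the single measured step, a 2.0-fold higher number from compound 1 to compound 2 (0.31 log units; beyond the scatter), is modest. Compound 3, `O=C(CCCCCCCc1ccccc1)C(F)(F)F`, differs from compound 2 in one place: phenyl in place of hexyl on a saturated chain carbon, seven bonds along the chain from a carbonyl carbon. Within the data shown here, the change again shortens the saturated chain, so the step from compound 1 to compound 2 is the only measured guide; it bears on the new step only in part, as that earlier step left hydrogen, while here phenyl enters. On that basis a modest step toward a higher number, a 2.0-fold higher number from compound 2 to compound 3 (0.31 log units; beyond the scatter), is expected in this assay. Compound 3 is therefore estimated at 1000 nM, with a range from 300 nM to 3500 nM.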

Compound 3, inhibition constant: 25 nM
Beside the measured number, compound 3's estimate is 40-fold (1.60 log units) above it, and the stated range ends above it.
By their numbers in this assay, from the lowest: compound 3; then compound 1; then compound 2.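

In this assay the earlier step, a 2.0-fold higher number from compound 1 to compound 2 (0.31 log units; beyond the scatter), was a modest move on a fully saturated chain, whereas the new step, a 20-fold lower number from compound 2 to compound 3 (1.29 log units; beyond the scatter), is a large move toward stronger inhibition. Hexyl and phenyl each hold six carbon atoms, so at this place, seven bonds along the chain from a carbonyl carbon, the heavy-atom count alone does not set the number, and the aromatic ring goes with a far lower value. No measurement at hand explains this gain.

Phenyl appears on only one chain length, so it remains open whether the gain would hold with a shorter or longer chain leading to the ring. A pyridine ring in its place, or a chlorine atom on the phenyl ring, also remains to be read.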